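Masking the Acid: Methyl Ester in a Dipeptidyl Peptidase 9 Series

The source may hold more compounds than are shown below. What is called first, only, known or untested is meant among the compounds shown, and "the series" means these compounds.

Compound 1 `CC#CCn1c(N2CCC[C@@H](N)C2)cc(=O)n(Cc2ccc(Cl)c(C(=O)O)c2)c1=O`: in an assay on isolated protein for inhibition of Dipeptidyl peptidase 9 (Homo sapiens), read by fluorescence, with stated times of 15 min and 20 min (a higher number here means a weaker inhibitor, a lower number a stronger inhibitor), compound 1 gives > 100 nM, a limit of the assay rather than a number.
Compound 2 `CC#CCn1c(N2CCC[C@@H](N)C2)cc(=O)n(Cc2cc(Br)cc(C(=O)O)c2)c1=O`: in this assay compound 2 gives > 100 nM, again a limit of the assay.

Going by the values given here, compound 2 therefore stands at the edge of what this assay reports, with no number of its own, and the one step that reaches it, a step that the two limits leave unreadable from compound 1 to compound 2, cannot be read because both ends sit at the limit (the limit of > 100 nM in this assay, at which 2 of the 2 values shown sit). From compound 2 the change methyl in place of hydrogen on an oxygen next to a carbonyl group gives compound 3 `CC#CCn1c(N2CCC[C@@H](N)C2)cc(=O)n(Cc2cc(Br)cc(C(=O)OC)c2)c1=O`. Among the compounds with values here, none of the measured steps concerns this change, so the expectation for compound 3 rests only on the position of compound 2 at the limit; a step that the limit leaves unreadable from compound 2 to compound 3 is expected, keeping compound 3 weak. Compound 3 is estimated at 400 nM, with a range from 100 nM to 5000 nM.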

Compound 3, half-maximal inhibitory concentration: > 100 nM
Compound 3: only a limit was reported (the forecaster's own chance of this, stated with the estimate: 75%); the middle value does not contradict the limit.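

Compound 3 gives > 100 nM in this assay, again a limit of the assay and not a number, so no new step can be read between compound 2 and compound 3: the limit of > 100 nM in this assay, at which 3 of the 3 values shown sit.

The compounds shown leave open how strongly compound 1, compound 2 and compound 3 actually inhibit, and whether methoxycarbonyl in place of carboxy changes anything.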